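Benzyl capping of the free hydroxy

A few compounds are considered here, and "the series" means these few. Any claim that something is new, unique, unknown or untested is made for them only; others in the source may bear on it.

Values in a functional assay on HeLa cells (Homo sapiens) for antiproliferative activity, read by sulforhodamine B assay (on this read-out higher numbers stand for weaker inhibition of growth and lower numbers for stronger inhibition of growth), so far:
compound 1 (`OCCC[C@@H]1O[C@H](COCc2ccccc2)[C@@H](OCc2ccccc2)[C@H](OCc2ccccc2)[C@H]1O`): > 50000 nM as a limit of the assay
compound 2 (`O[C@@H]1[C@@H](OCc2ccccc2)[C@H](OCc2ccccc2)[C@@H](COCc2ccccc2)O[C@H]1Cc1ccccc1`): 17400 nM as a measured number

For the measured compounds named here, compound 2 holds the only true number so far, the other reading being a limit. Compound 3 (`c1ccc(COC[C@H]2O[C@@H](Cc3ccccc3)[C@H](OCc3ccccc3)[C@@H](OCc3ccccc3)[C@@H]2OCc2ccccc2)cc1`) differs from compound 2 by benzyl in place of hydrogen on an oxygen on a saturated carbon (hydroxy to benzyloxy). Going by the values given here, the only guide is an at least 2.8-fold lower number from compound 1 to compound 2 (0.45 log units; beyond the scatter) at a different place, beyond the scatter, and no measured step touches this oxygen. A modest move towards weaker inhibition in this assay is therefore expected, though possibly none beyond the scatter. The expected size is a 1.5-fold higher number from compound 2 to compound 3 (0.17 log units; within the scatter) on this estimate. For compound 3 the expected value is 26000 nM within an estimated range of 9000 nM to 70000 nM overall.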

Compound 3, concentration for 50% growth inhibition: > 50000 nM
Compound 3: a limit, no number; the forecaster's own chance of this, stated with the estimate: 35%; at least 1.9-fold (0.28 log units) between middle value and limit.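

In this assay, benzyl on this oxygen gives an at least 2.8-fold higher number from compound 2 to compound 3 (0.45 log units; beyond the scatter) and so shows that the hydroxy to benzyloxy change, at this second place on the shared core, does not retain the measured growth inhibition of compound 2. The reading for compound 3 is a limit, not a number. Only a minimum size can therefore be read for this step: the limit of > 50000 nM in this assay, at which 2 of the 3 values shown sit.

On these data alone, whether methyl on this oxygen, or an amine in place of the hydroxy, would retain growth inhibition remains open. The same applies to a longer chain in place of benzyl.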